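The source may report more compounds than this note shows. Statements on the series, on what has been measured and on what is new or still open speak of the compounds shown alone.

Compound 3 `O=C(O)/C=C/c1ccncc1-c1ccc2ccccc2c1` holds the lowest number of the two that have been measured in an assay on a protein complex for inhibition of CDK8/Cyclin C (Homo sapiens), with a stated time of 1 h (on this read-out higher numbers stand for weaker inhibition and lower numbers for stronger inhibition), where compound 3 gives 5 nM. Compound 1 `CNC(=O)/C=C/c1ccncc1-c1ccc2ccccc2c1` differs from it only at the carbonyl carbon, carrying methylamino where compound 3 carries hydroxy, and in this assay compound 1 gives 12.4 nM. Compound 2 `NNC(=O)COc1ccncc1-c1ccc2ccccc2c1` belongs to the same family but has no usable result, since in this assay compound 2 gives "not determined" (no result reported).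

Compound 4 `O=C(O)CCNC(=O)/C=C/c1ccncc1-c1ccc2ccccc2c1` is reached from compound 3 by the change ((2-carboxyethyl)amino in place of hydroxy on a carbonyl carbon). Among the measured compounds shown here, the only measured step that speaks to this place is a 2.5-fold lower number from compound 1 to compound 3 (0.39 log units; beyond the scatter), which shows that an amide made from methylamine gave a somewhat higher number than the free acid. Compound 4 returns to an amide at that carbon, while the chain that enters ends in a carboxy of its own. Because the step of a 2.5-fold lower number from compound 1 to compound 3 (0.39 log units; beyond the scatter) was only modest, the expected change for compound 4 is a small rise in the number, a 2.0-fold higher number from compound 3 to compound 4 (0.30 log units; within the scatter). The value expected for compound 4 in this assay is 10 nM, within a range from 3 nM to 35 nM.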

Compound 4, half-maximal inhibitory concentration: 870 nM
Compound 4: the middle estimate sits 87-fold (1.94 log units) below what was measured; measured number above the stated range.
By their numbers in this assay, from the lowest: compound 3; then compound 1; then compound 4.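

In this assay, the carbonyl carbon proved much less tolerant than the earlier step of a 2.5-fold lower number from compound 1 to compound 3 (0.39 log units; beyond the scatter) had suggested: putting (2-carboxyethyl)amino in place of hydroxy gave a 170-fold higher number from compound 3 to compound 4 (2.24 log units; beyond the scatter) and moved the number far beyond the scatter. The second comparison narrows down where this loss appears, since adding carboxymethyl to the saturated chain carbon bound to the amide-type nitrogen gave a 70-fold higher number from compound 1 to compound 4 (1.85 log units; beyond the scatter) even though both compounds are amides, so the amide link alone does not go with a number this high. The data at hand offer no measurement that explains the size of this rise.

The compounds shown leave open whether the high number goes with the carboxy group at the end of the chain or with the longer chain itself, and an amide with a plain propyl chain, or one whose chain ends in a methyl ester or an amine, would help separate the two. They also leave open whether a shorter chain ending in a carboxylic acid would bring the number back down.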